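Compound 4: Dihydroxyphenyl in Place of Dichlorophenyl

The source may report more compounds than this note shows. Statements on the series, on what has been measured and on what is new or still open speak of the compounds shown alone.

Compound 1 `COc1ccc(OC)c(/C=N/NC(=O)Nc2ccc(Oc3ccnc(-c4nncn4CCN(C)C)c3)c(F)c2)c1` gives 1950 nM.
Compound 2 `CN(C)CCn1cnnc1-c1cc(Oc2ccc(NC(=O)N/N=C/c3ccc(Cl)cc3)cc2F)ccn1` gives 780 nM.
Compound 3 `CN(C)CCn1cnnc1-c1cc(Oc2ccc(NC(=O)N/N=C/c3ccc(Cl)cc3Cl)cc2F)ccn1` gives 810 nM.

In a functional assay on A549 cells (Homo sapiens) for cytotoxicity, read by MTT assay, with a stated time of 72 h (a higher number here means a weaker inhibitor, a lower number a stronger inhibitor), compound 3 stands second highest of the three numbers. Its nearest neighbour is compound 2, with a 1.0-fold higher number from compound 2 to compound 3 (0.02 log units; within the scatter); its furthest is compound 1, with a 2.4-fold lower number from compound 1 to compound 3 (0.38 log units; beyond the scatter).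

Compound 4 `CN(C)CCn1cnnc1-c1cc(Oc2ccc(NC(=O)N/N=C/c3ccc(O)cc3O)cc2F)ccn1` differs from compound 3 in one place: 2,4-dihydroxyphenyl in place of 2,4-dichlorophenyl on a carbon with a double bond to nitrogen.

For the measured compounds named here, two measured steps bear on a change of the aryl group at this carbon: a 2.5-fold lower number from compound 1 to compound 2 (0.40 log units; beyond the scatter) and a 2.4-fold lower number from compound 1 to compound 3 (0.38 log units; beyond the scatter), both modest, showing that this aryl group matters. The step of a 1.0-fold higher number from compound 2 to compound 3 (0.02 log units; within the scatter) shows a single chloro added there changed nothing beyond the scatter. Going by the values given here, no measured compound carries hydroxy groups here, so the direction rests on compound 1, which with dimethoxyphenyl gave 1950 nM.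

Compound 4 is therefore estimated at 1800 nM, expected between 700 nM and 4500 nM. That is an expected step of a 2.2-fold higher number from compound 3 to compound 4 (0.35 log units; beyond the scatter).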

Compound 4, half-maximal inhibitory concentration: 12700 nM
Beside the measured number, compound 4's estimate is 7.1-fold (0.85 log units) below it; measured number outside the range, above it.
By their numbers in this assay, from the lowest: compounds 2 and 3 (each within the scatter of the next); then compound 1; then compound 4.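

In this assay, 2,4-dihydroxyphenyl on this carbon brings the first large steps seen at this position, a 16-fold higher number from compound 3 to compound 4 (1.20 log units; beyond the scatter) and a 16-fold higher number from compound 2 to compound 4 (1.21 log units; beyond the scatter), while the earlier aryl changes gave modest steps or none beyond the scatter. Even the step nearest to it, a 6.5-fold higher number from compound 1 to compound 4 (0.81 log units; beyond the scatter), is beyond the scatter, so this group separates from all three other aryl groups shown. Nothing measured here accounts for this result. The compounds shown leave open whether a single hydroxy group would give the same rise, and how an amine or a carboxylic acid on this aryl ring would read.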